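This account rests on a few compounds, and the source may have more. Where it says the series, first, only, none or still open, it means among the compounds named here.

Compound 1 `COc1cc(OC)c2c(=O)n(-c3cccc(C(N)=O)c3)ccc2c1` and compound 2 `COc1cc2c(c(OC)c1)C(=O)N(c1cccc(C(=O)N3CCCCC3)c1)CC2` share a core carrying two methoxy groups, and differ in the amide group on the attached benzene ring and in how the core ring is built. In a functional assay on A549 cells (Homo sapiens) for antiproliferative activity, read by MTT assay, with a stated time of 72 h (on this read-out higher numbers stand for weaker inhibition and lower numbers for stronger inhibition), compound 1 gives 31300 nM, and compound 2 gives 23400 nM. Compound 2 thus stands at one end of the two numbers seen, but its gap to compound 1 lies within the usual scatter, so the two cannot be told apart on these data. Compound 3 `COc1cc(O)c2c(c1)CCN(c1cccc(C(=O)N3CCCCC3)c1)C2=O` is the next step from compound 2: hydrogen in place of methyl on an oxygen on an aromatic ring. For the measured compounds named here, no measured pair in this set tells what such a change does, so there is no ground to expect a shift beyond the scatter in either direction. Compound 3 is therefore estimated at 22000 nM, with a plausible range from 9000 nM to 55000 nM, and the step from compound 2 is expected to be a 1.1-fold lower number from compound 2 to compound 3 (0.03 log units; within the scatter).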

Compound 3, half-maximal inhibitory concentration: 13200 nM
The estimate for compound 3 lay 1.7-fold (0.22 log units) above the measured number, and the stated range covers the measured number.
By their numbers in this assay, from the lowest: compounds 3, 2 and 1 (each within the scatter of the next, the first and the last beyond it).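

For the compounds shown here, replacing methoxy with hydroxy, that is, hydrogen in place of methyl on an oxygen on an aromatic ring, gives a 1.8-fold lower number from compound 2 to compound 3 (0.25 log units; within the scatter) in this assay and provides the first pair in this set that differs in only one place. At this position, then, the methyl can be removed without the number moving beyond the usual scatter, so compound 2 and compound 3 cannot be told apart on these data. Nothing available explains this result or links it to any property of the group.

The compounds shown leave open whether the remaining methoxy on the shared core would tolerate the same change. They also leave open what a longer chain on this oxygen, such as ethoxy, or an amine in place of the hydroxy would do.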